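Trypsin inhibition: shortening a propyl side chain to methyl

A few compounds are considered here, and "the series" means these few. Any claim that something is new, unique, unknown or untested is made for them only; others in the source may bear on it.

Compound 1 `O=C(CCc1ccc2[nH]c(-c3ccc(Cl)s3)nc2c1)Nc1ccc(N2CCOCC2=O)cc1F`, compound 2 `O=C(CNC(=O)c1ccc(Cl)s1)Nc1ccc(N2CCOCC2=O)cc1` and compound 3 `CCC[C@@H](NC(=O)c1ccc(Cl)s1)C(=O)Nc1ccc(N2CCOCC2=O)c(C)c1` were tested in an assay on isolated protein for inhibition of Trypsin (Homo sapiens); on this read-out higher numbers stand for weaker inhibition and lower numbers for stronger inhibition. For compound 1 the result is only a limit of the assay, > 10000 nM. For compound 2 the result is likewise a limit, > 10000 nM. For compound 3 the result is also a limit, > 10000 nM. Compound 3 therefore sits at the limit of > 10000 nM in this assay, at which 3 of the 3 values shown sit, and no ordering among the three can be drawn. Compound 4 `Cc1cc(NC(=O)[C@@H](C)NC(=O)c2ccc(Cl)s2)ccc1N1CCOCC1=O` differs from compound 3 by hydrogen in place of ethyl on a saturated chain carbon, two bonds along the chain from an amide-type nitrogen and a carbonyl carbon. Going by the values given here, no measured pair shows what such a change does here. For compound 4 the step that the limit leaves unreadable from compound 3 to compound 4 is expected to stay within the scatter. Compound 4 is thus estimated at 15000 nM, with a range of 5000 nM to 50000 nM, most probably reported again only as a limit.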

Compound 4, half-maximal inhibitory concentration: > 10000 nM
Compound 4 was reported as a limit; the forecaster's own chance of this, stated with the estimate: 85%; the middle value is on the limit's open side.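

Compound 3 and compound 4 both end at a limit of the assay, so no step between them can be read: the limit of > 10000 nM in this assay, at which 4 of the 4 values shown sit.

Going by these compounds, what the change from propyl to methyl does in this assay stays open, as does what would give a value short of that limit.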